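The source may report more compounds than this note shows. Statements on the series, on what has been measured and on what is new or still open speak of the compounds shown alone.

Measured so far:
- compound 1 `COc1ccc2c(=O)c(/C=C/C(=O)Nc3cccc(Cl)c3)coc2c1` — > 200000 nM
- compound 2 `COc1ccc2c(=O)c(/C=C/C(=O)Nc3ccc(C)cc3)coc2c1` — > 200000 nM

In a functional assay on L02 cells (Homo sapiens) for inhibition, read by MTT assay, with a stated time of 48 h (a lower number here means a stronger inhibitor, a higher number a weaker inhibitor), compound 1 gives a value that is only a limit of the assay, > 200000 nM. In this assay compound 2 likewise gives only a limit, > 200000 nM. Among the measured compounds shown here, the one step joining them, a step that the two limits leave unreadable from compound 1 to compound 2, cannot be read in size or direction, since both ends sit at the limit; the line the limit of > 200000 nM in this assay, at which 2 of the 2 values shown sit, records this.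

Compound 3 `CCOc1ccc(NC(=O)/C=C/c2coc3cc(OC)ccc3c2=O)cc1` is not yet measured. It differs from compound 2 by ethoxy in place of methyl on an aromatic carbon. For the measured compounds named here, no measured step touches an ethoxy group, and the only measured step, a step that the two limits leave unreadable from compound 1 to compound 2, is itself unreadable, so nothing here indicates that a change on this phenyl ring moves the value out of the region where the assay reports a limit.

Compound 3 is therefore expected to give a value at or near the same limit in this assay, an estimated 200000 nM, within 60000 nM to 500000 nM. The expected step of a number no higher from compound 2 to compound 3 (the limit leaves the size open) is estimated as none beyond the scatter.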

Compound 3, half-maximal inhibitory concentration: > 200000 nM
Compound 3: a limit, no number (the forecaster's own chance of this, stated with the estimate: 80%); the middle value sits exactly at the limit.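

In this assay compound 3 gives > 200000 nM as a limit of the assay, not a number. Among the compounds shown here, no step among compound 1, compound 2 and compound 3 can be read, because all three values stand at one limit: the limit of > 200000 nM in this assay, at which 3 of the 3 values shown sit. It remains open whether in this assay any change on the phenyl ring of these compounds would give a number rather than a limit.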